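Silyl ether in place of bromine on a quinoline amide

The source may report more compounds than this note shows. Statements on the series, on what has been measured and on what is new or still open speak of the compounds shown alone.

Measured so far:
compound 1 `O=C(NCc1cc(C(F)(F)F)cc(C(F)(F)F)c1)c1c(CBr)nc2ccccc2c1-c1ccccc1`, an in vitro assay on UC11MG cells for binding affinity to Substance-P receptor (Homo sapiens), read by radioligand binding; a lower number here means a stronger inhibitor, a higher number a weaker inhibitor: 0.01 nM
compound 2 `CN(Cc1cc(C(F)(F)F)cc(C(F)(F)F)c1)C(=O)c1c(CBr)nc2ccccc2c1-c1ccccc1`, this assay: 52 nM

Compound 1 stands at the lowest of the two numbers; its nearest neighbour is compound 2, and the step is a 5200-fold higher number from compound 1 to compound 2 (3.72 log units; beyond the scatter), a change of methyl in place of hydrogen on an amide-type nitrogen. Compound 3 `CC(C)(C)[Si](C)(C)OCc1nc2ccccc2c(-c2ccccc2)c1C(=O)NCc1cc(C(F)(F)F)cc(C(F)(F)F)c1` is not yet measured. It differs from compound 1 in this way: a group of 8 heavy atoms (6 carbon, 1 oxygen, 1 silicon; no ring) in place of one bromine atom, on a saturated chain carbon bound to an aromatic carbon. Among the measured compounds shown here, the amide hydrogen of compound 1 is kept in compound 3, so the one measured step, from compound 1 to compound 2, touches a different place and does not bear on the change to compound 3. For the measured compounds named here, there is therefore no measured step that tells how much the number should move, in either direction. The expectation for compound 3 rests on compound 1 alone, with wide uncertainty. Compound 3 is estimated at 0.5 nM, within a range from 0.01 nM to 30 nM. This expected step, a 50-fold higher number from compound 1 to compound 3 (1.70 log units; beyond the scatter), is a guess, and the measurement will decide.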

Compound 3, half-maximal inhibitory concentration: 17 nM
For compound 3 the middle estimate is 34-fold (1.53 log units) below the measured one; the range from low to high includes it.
By their numbers in this assay, from the lowest: compound 1; then compound 3; then compound 2.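

In this assay, the result shows that the amide hydrogen is not the only place where a single change on compound 1 moves the number a long way: replacing bromine with the silyl ether on the saturated chain carbon bound to an aromatic carbon gives a 1700-fold higher number from compound 1 to compound 3 (3.23 log units; beyond the scatter). Among the compounds shown here, until now, the only step known was at the amide nitrogen, where methyl in place of hydrogen gives a 5200-fold higher number from compound 1 to compound 2 (3.72 log units; beyond the scatter), so both places changed so far are now known to carry large steps away from compound 1. Nothing given here explains why the silyl ether step is so large.

This single swap replaces one bromine atom with a group of 8 heavy atoms that brings in oxygen, silicon and six carbons together, so the compounds shown cannot tell whether the loss of bromine or the arrival of the larger group accounts for the step. Going by these compounds, a chlorine atom, a hydroxyl or a methoxy group in place of the bromine on that carbon would be needed to separate these, and how such groups would fare remains open.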